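Cyclopropylmethyl for cyclopropyl on the distal ring

The source may hold more compounds than are shown below. What is called first, only, known or untested is meant among the compounds shown, and "the series" means these compounds.

Notes on a small set of dimethylaminomethyl benzyl and diaryl ether compounds. Compound 1 `CSc1ccc(Cc2ccccc2CN(C)C)cc1` gives 11000 nM in an assay on HEK293 cells for inhibition of sodium-dependent dopamine transporter (Homo sapiens); on this read-out higher numbers stand for weaker inhibition and lower numbers for stronger inhibition. Compound 2 `CN(C)Cc1ccccc1Oc1ccc(C#N)cc1` has "not determined" (no result reported) in this assay. Compound 3 `CN(C)Cc1ccccc1Oc1ccc(C2CC2)cc1` gives 4200 nM in this assay, the lowest of the two numbers, and the gap to compound 1 lies beyond the scatter. Going by the values given here, no single-point step between measured compounds is available. Compound 4 `CN(C)Cc1ccccc1Oc1ccc(CC2CC2)cc1` differs from compound 3 by cyclopropylmethyl in place of cyclopropyl on an aromatic carbon. Among the compounds with values here, with no comparable step to lean on, the expected change in this assay is small, in either direction or none beyond the scatter. Compound 4 is estimated at 4000 nM in this assay, within 1500 nM to 12000 nM, an expected step of a 1.1-fold lower number from compound 3 to compound 4 (0.02 log units; within the scatter).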

Compound 4, half-maximal inhibitory concentration: 16000 nM
Compound 4: middle estimate off by 4.0-fold (0.60 log units), on the low side, and the stated range ends below it.
By their numbers in this assay, from the lowest: compound 3; then compounds 1 and 4 (each within the scatter of the next).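

Cyclopropylmethyl in place of cyclopropyl gives a 3.8-fold higher number from compound 3 to compound 4 (0.58 log units; beyond the scatter) in this assay. This aromatic carbon, para to a large group, therefore responds to a growth from 3 to 4 heavy atoms, even though the three-membered ring stays and no hydrogen-bond donor or acceptor enters. Nothing available bears on the reason for this rise.

Still open, from the compounds shown here alone, is whether the number rises further with a longer chain such as cyclopropylethyl. Also open, going by these compounds, is whether isopropyl or methoxy on this carbon would stand nearer compound 3 or compound 4.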